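Notes on the pendant aryl group of compound 2

A few compounds are considered here, and "the series" means these few. Any claim that something is new, unique, unknown or untested is made for them only; others in the source may bear on it.

Measured compounds, antiproliferative read-out on the same cell line:
- compound 1, `COc1cc(CCc2ccc(Cl)cc2)cc(OC)c1O`: 330 nM
- compound 2, `COc1ccccc1CCc1cc(OC)c(O)c(OC)c1`: 14500 nM

In a functional assay on HCT-116 cells (Homo sapiens) for antiproliferative activity, read by MTT assay, with a stated time of 72 h (on this read-out higher numbers stand for weaker inhibition and lower numbers for stronger inhibition), compound 2 gives 14500 nM. Compound 2 stands at the highest number of the two measured; the nearest is compound 1, which in this assay gives 330 nM, a difference well beyond the scatter. Compound 1 and compound 2 differ in two places at once on the pendant ring. Going by the values given here, no single-change step between them is available, so their two values are all that can be said of that pair.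

Compound 3, `COc1cc(CCc2ccccc2)cc(OC)c1O`, is not yet measured in this assay. It differs from compound 2 in one place: hydrogen in place of methoxy on an aromatic carbon. The methoxy leaves and hydrogen enters on an aromatic carbon of a six-membered aromatic ring of carbon only, ortho to a large group.

Among the compounds with values here, no single-change step between measured compounds is available, so the size of this step rests on expectation only. Compound 3 is expected to give a lower number than compound 2, because compound 1 gives 330 nM with a differently substituted pendant ring and compound 3 sits between the two in substitution. The step expected is a 5.8-fold lower number from compound 2 to compound 3 (0.76 log units; beyond the scatter). For compound 3 the estimate in this assay is 2500 nM, with a range from 600 nM to 10000 nM.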

Compound 3, half-maximal inhibitory concentration: 530 nM
Beside the measured number, compound 3's estimate is 4.7-fold (0.67 log units) above it; measured number outside the range, below it.
By their numbers in this assay, from the lowest: compounds 1 and 3 (each within the scatter of the next); then compound 2.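

In this assay, hydrogen in place of methoxy on an aromatic carbon, ortho to a large group, gives a 27-fold lower number from compound 2 to compound 3 (1.44 log units; beyond the scatter), so in this pair the high number of compound 2 goes with that single methoxy and not with the shared core. Hydrogen in place of chloro on an aromatic carbon gives a 1.6-fold higher number from compound 1 to compound 3 (0.21 log units; within the scatter), so this pair shows no separation between chloro and hydrogen at the chloro-bearing carbon, and the pendant ring does not respond alike to every change made on it. The cost of a substituent on this ring therefore depends on which group is present and where it stands, at least across these two steps, and nothing available speaks to what lies behind the large methoxy step.

As far as these compounds go, it remains open whether the large step belongs to methoxy itself or would also appear with a smaller group such as fluoro or hydroxy, or with a larger one such as ethoxy, at the same carbon. Also open, from the compounds shown here alone, is how an amine or a carboxylic acid on the pendant ring would read out in this assay.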